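A few compounds are considered here, and "the series" means these few. Any claim that something is new, unique, unknown or untested is made for them only; others in the source may bear on it.

Compound 1 `COc1ccccc1-c1cccc(S(=O)(=O)N2CCC(N3CCC(C)CC3)CC2)c1`: in an ADME assay on HCT-116 cells (Homo sapiens) for cytotoxicity, read by CellTiter-Glo, with a stated time of 72 h (a lower number here means a stronger inhibitor, a higher number a weaker inhibitor), compound 1 gives > 5000 nM, a limit of the assay.
Compound 2 `CC1CCN(C2CCN(S(=O)(=O)c3cccnc3Cl)CC2)CC1`: in this assay compound 2 gives > 10000 nM, a limit of the assay.
Compound 3 `CC1CCN(C2CCN(S(=O)(=O)c3cccc(-c4ccc(Cl)cc4)c3)CC2)CC1`: in this assay compound 3 gives > 5000 nM, a limit of the assay.

Compound 2 stands at the limit of > 10000 nM in this assay, at which 1 of the 3 values shown sits, while the two other values sit at the limit of > 5000 nM in this assay, at which 2 of the 3 values shown sit; none of the three is a number. Compound 4 `CC1CCN(C2CCN(S(=O)(=O)c3cccnc3)CC2)CC1` differs from compound 2 by hydrogen in place of chloro on an aromatic carbon. For the measured compounds named here, the only measured step, a step that the two limits leave unreadable from compound 1 to compound 3, concerns another part of the shared core and its size cannot be read, so no measured step bears on the change. No direction can be read for this assay, and the expected outcome is again a limit. Compound 4 is expected at 15000 nM, with a range from 5000 nM to 50000 nM, which is estimated to mean a step that the limit leaves unreadable from compound 2 to compound 4.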

Compound 4, half-maximal inhibitory concentration: > 10000 nM
Compound 4: a limit, no number; the forecaster's own chance of this, stated with the estimate: 90%; the middle value lies beyond the limit too.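

In this assay compound 2 and compound 4 each give a limit and not a number, so no step can be read between them. The compounds shown leave open whether any change to the shared core would give a measurable value in this assay.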